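Chloro-for-hydrogen swap on a fused core: growth inhibition

The source may report more compounds than this note shows. Statements on the series, on what has been measured and on what is new or still open speak of the compounds shown alone.

Measured compounds:
compound 1, `ClCc1ccc(Cn2cnc3nc(Cl)nc(Cl)c32)cc1`, 3310 nM
compound 2, `ClCc1ccccc1Cn1cnc2ncnc(Cl)c21`, 20400 nM
compound 3, `ClCc1ccccc1Cn1cnc2nc(Cl)nc(Cl)c21`, 35500 nM

In a functional assay on SF-295 cells (Homo sapiens) for cytotoxicity, read by sulforhodamine B assay, with a stated time of 48 h (on this read-out lower numbers stand for stronger inhibition of growth and higher numbers for weaker inhibition of growth), compound 1 gives the lowest of the three numbers. Compound 3 and compound 2 share one core and differ by a single change, (hydrogen in place of chloro on an aromatic carbon), which produced a 1.7-fold lower number from compound 3 to compound 2 (0.24 log units; within the scatter). Compound 1 carries a different core; the difference between the two cores is not broken down here. Compound 4, `ClCc1ccc(Cn2cnc3ncnc(Cl)c32)cc1`, has not yet been measured; it differs from compound 1 by hydrogen in place of chloro on an aromatic carbon, the same change as between compound 3 and compound 2. Resting on that earlier step, compound 4 is expected to show a 1.7-fold lower number from compound 1 to compound 4 (0.22 log units; within the scatter), because compound 1 gives 3310 nM and the step from compound 3 to compound 2 was small. The estimate for compound 4 is 2000 nM, between 700 nM and 6000 nM.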

Compound 4, concentration for total growth inhibition: 5010 nM
Beside the measured number, compound 4's estimate is 2.5-fold (0.40 log units) below it; measured number inside the range.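

In this assay, hydrogen in place of chloro on the aromatic carbon between two ring nitrogen atoms gives a 1.5-fold higher number from compound 1 to compound 4 (0.18 log units; within the scatter). The step on the other core also lies within the scatter, and the two steps do not differ beyond it: the same change on two cores in this assay, a 1.7-fold lower number (0.24 log units; within the scatter) from compound 3 to compound 2 and a 1.5-fold higher number (0.18 log units; within the scatter) from compound 1 to compound 4, 2.6-fold (0.42 log units) apart, within the scatter of two such steps. The change therefore stays small on both cores, but the opposite directions of the two steps cannot be read as a real difference, and two cores do not show that the same would hold on a third.

The compounds shown leave open whether an amine or a methoxy group on that aromatic carbon would give a number different from those seen with chloro or hydrogen.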